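The source may report more compounds than this note shows. Statements on the series, on what has been measured and on what is new or still open speak of the compounds shown alone.

Measured so far in a functional assay on MCF7 cells (Homo sapiens) for antiproliferative activity, read by MTT assay, with a stated time of 72 h; a lower number here means a stronger inhibitor, a higher number a weaker inhibitor:
- compound 1 `CC1=CC[C@H]2[C@H](CC[C@]2(C)O)C(C)(C)[C@@H]1CC[C@H]1[C@]2(C)CC[C@H](OC(=O)c3ccncc3)C(C)(C)O[C@H]2CC[C@@]1(C)O`: 25300 nM
- compound 2 `CC1=CC[C@H]2[C@H](CC[C@]2(C)O)C(C)(C)[C@@H]1CC[C@H]1[C@]2(C)CC[C@H](OC(=O)c3ccccc3Cl)C(C)(C)O[C@H]2CC[C@@]1(C)O`: 12100 nM

Compound 2, at 12100 nM, holds the lower of the two numbers in this assay. Next in the series is compound 3 `CC1=CC[C@H]2[C@H](CC[C@]2(C)O)C(C)(C)[C@@H]1CC[C@H]1[C@]2(C)CC[C@H](OC(=O)c3ccc(C(F)(F)F)cc3F)C(C)(C)O[C@H]2CC[C@@]1(C)O`, which keeps the shared core and has 2-fluoro-4-(trifluoromethyl)phenyl in place of 2-chlorophenyl on a carbonyl carbon. Among the measured compounds shown here, only one measured step bears on this place, a 2.1-fold lower number from compound 1 to compound 2 (0.32 log units; beyond the scatter), and it was modest, with pyridin-4-yl leaving and 2-chlorophenyl entering. One step is a thin guide to a change between two substituted phenyl groups, so no step beyond the scatter is expected in this assay. The estimated step is a 1.2-fold lower number from compound 2 to compound 3 (0.08 log units; within the scatter). For compound 3 the expected value is 10000 nM, with an estimated range of 4000 nM to 25000 nM.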

Compound 3, half-maximal inhibitory concentration: > 50000 nM
Compound 3: only a limit was reported; the forecaster's own chance of this, stated with the estimate: 5%; at least 5.0-fold (0.69 log units) between middle value and limit.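

Swapping one substituted phenyl group for another on the carbonyl carbon is not a neutral change in this assay: the series moves by an at least 4.1-fold higher number from compound 2 to compound 3 (0.61 log units; beyond the scatter), so the gain seen with 2-chlorophenyl does not extend to every substituted phenyl group shown. Compound 3 reads > 50000 nM, which is a limit and not a number: the limit of > 50000 nM in this assay, at which 1 of the 3 values shown sits.

Against the pyridin-4-yl group the reading is an at least 1.9-fold higher number from compound 1 to compound 3 (0.29 log units; that floor lies within the scatter), a floor that does not separate the two compounds.

Compound 3 both exchanges chlorine for fluorine and adds a trifluoromethyl group, and the compounds shown do not apportion the loss between these two differences. Also open, on these data alone, is how a plain phenyl, a 2-fluorophenyl or a short chain ending in an amine would read on the same carbonyl carbon.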